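Half-life notes on three substituted compounds and one to come

This account rests on a few compounds, and the source may have more. Where it says the series, first, only, none or still open, it means among the compounds named here.

Compound 1 `CC(O)c1nc([C@@H](O)[C@H](O)[C@H](O)CO)c[nH]1`: 4.4 h
Compound 2 `CN(C)C(=O)c1nc([C@@H](O)[C@H](O)[C@H](O)CO)c[nH]1`: 4 h
Compound 3 `OC[C@@H](O)[C@@H](O)[C@H](O)c1c[nH]c(-c2cscn2)n1`: 4.2 h

All three values come from an ADME assay on the whole organism (strain 129/SvEvBrd x C57BL/6) for metabolic stability, with Mus musculus as the target; on this read-out higher numbers stand for a longer-lived compound and lower numbers for a shorter-lived compound. Compound 3, at 4.2 h, cannot be separated from either of the other two, since its gaps to both stay within the scatter.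

The open step leads to compound 4 `OC[C@@H](O)[C@@H](O)[C@H](O)c1c[nH]c(-c2ncc[nH]2)n1`, and the change is 1H-imidazol-2-yl in place of 1,3-thiazol-4-yl on an aromatic carbon. In words, this is 1H-imidazol-2-yl in place of 1,3-thiazol-4-yl on an aromatic carbon, between two ring nitrogen atoms.

Among the measured compounds shown here, no measured compound carries 1H-imidazol-2-yl, so the data hold no direct reading of this group. The nearest evidence is the set of replacements made on the same kind of aromatic carbon: a 1.1-fold lower number from compound 1 to compound 2 (0.04 log units; within the scatter), a 1.0-fold lower number from compound 1 to compound 3 (0.02 log units; within the scatter) and a 1.1-fold higher number from compound 2 to compound 3 (0.02 log units; within the scatter). All three are small, and none of the three compounds goes against that. Two of these steps involve 1,3-thiazol-4-yl, the group that leaves here. On that basis, no step beyond the scatter is expected in this assay, and no direction can be assigned. The estimated step is a 1.0-fold lower number from compound 3 to compound 4 (0.01 log units; within the scatter). Compound 4 is expected at 4.1 h, with an estimated range of 2.3 h to 7 h.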

Compound 4, half-life: 3.2 h
Estimate against measurement, compound 4: 1.3-fold (0.11 log units) above; the measured number falls inside the stated range.
By their numbers in this assay, from the lowest: compounds 4, 2, 3 and 1 (each within the scatter of the next).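

In this assay, among the compounds shown here, placing 1H-imidazol-2-yl on the aromatic carbon between two ring nitrogen atoms in place of 1,3-thiazol-4-yl gives a 1.3-fold lower number from compound 3 to compound 4 (0.12 log units; within the scatter), so exchanging a ring with 0 hydrogen-bond donors for one with 1 hydrogen-bond donor, at the same count of 5 heavy atoms, produces no step that can be separated from the scatter. For the compounds shown here, the new group is also not separated from the two non-ring groups, with a 1.3-fold lower number from compound 2 to compound 4 (0.10 log units; within the scatter) and a 1.4-fold lower number from compound 1 to compound 4 (0.14 log units; within the scatter), which extends the flat picture at this position to four different groups, with no compound going against it. The data offer no explanation for this insensitivity.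

From the compounds shown here alone, whether an amine, a carboxylic acid or a longer alkyl chain at this position would give a step beyond the scatter remains open. All four compounds also carry the same group of 8 heavy atoms on the shared core, so they say nothing about how replacing that group would affect the read-out.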